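Shortening Two Chains on a Weakly Active Core

A few compounds are considered here, and "the series" means these few. Any claim that something is new, unique, unknown or untested is made for them only; others in the source may bear on it.

Compound 1 `COCc1nc(C)c2c(C)nnc(O)n12` and compound 2 `CCCCc1nnc(O)n2c(CCC)nc(C)c12` share one core. In a functional assay for inhibition, with Homo sapiens as the target (a higher number here means a weaker inhibitor, a lower number a stronger inhibitor), compound 1 gives only a limit, > 48000 nM. Compound 2 likewise reaches only a limit in this assay, > 48000 nM. Both therefore sit at the limit of > 48000 nM in this assay, at which 2 of the 2 values shown sit, the edge of what this measurement can report. Compound 3 `CCCc1nc(C)c2c(CC)nnc(O)n12` differs from compound 2 by hydrogen in place of ethyl on a saturated chain carbon, two bonds along the chain from an aromatic carbon. Nothing measured shows how this change acts, so no step beyond the usual scatter is expected in this assay. Compound 3 is therefore expected at about 48000 nM, most likely again a limit, between 20000 nM and 150000 nM. The estimated step is a number no higher from compound 2 to compound 3 (the limit leaves the size open).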

Compound 3, half-maximal inhibitory concentration: 15600 nM
Beside the measured number, compound 3's estimate is 3.1-fold (0.49 log units) above it, and the stated range ends above it.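

Cutting the chain at this position from butyl to ethyl gives an at least 3.0-fold lower number from compound 2 to compound 3 (0.48 log units; beyond the scatter) in this assay. This position therefore responds to chain length, and here the shorter chain goes with the stronger inhibitor, a link the two earlier limits could not reveal. The full size of the gain stays unknown because compound 2 gives only a limit: the limit of > 48000 nM in this assay, at which 2 of the 3 values shown sit.

One step cannot show whether shortening this chain further would help or whether the gain would hold in another setting. Nor do the compounds shown reveal how an amine or a carboxylic acid at this position would behave.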